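The source may report more compounds than this note shows. Statements on the series, on what has been measured and on what is new or still open speak of the compounds shown alone.

Of the compounds shown here, three have been measured in a functional assay on MV4-11 cells (Homo sapiens) for antiproliferative activity, read by CCK-8 assay, with a stated time of 72 h; on this read-out lower numbers stand for stronger inhibition and higher numbers for weaker inhibition. Compound 1 `Cn1cc(-c2ccccc2Oc2ccccc2)c2cc(C(=O)NCc3ccc(C(=O)Nc4ccccc4N)cc3)[nH]c2c1=O` gives 80 nM, compound 2 `CC(C)Oc1ccccc1-c1cn(C)c(=O)c2[nH]c(C(=O)NCc3ccc(C(=O)Nc4ccccc4N)cc3)cc12` gives 130 nM, and compound 3 `Cn1cc(-c2cccc(F)c2)c2cc(C(=O)NCc3ccc(C(=O)Nc4ccccc4N)cc3)[nH]c2c1=O` gives 210 nM, the highest of the three numbers, although its distance from compound 2 lies within the scatter and only its distance from compound 1 lies beyond it. Compound 4 `COc1ccccc1-c1cn(C)c(=O)c2[nH]c(C(=O)NCc3ccc(C(=O)Nc4ccccc4N)cc3)cc12` carries 2-methoxyphenyl in place of 3-fluorophenyl on an aromatic carbon. The step that bears most directly on this change is a 1.6-fold higher number from compound 2 to compound 3 (0.21 log units; within the scatter), which the new change largely reverses, while a 1.6-fold higher number from compound 1 to compound 2 (0.21 log units; within the scatter) shows that exchanging the group on the oxygen stayed within the scatter. A modest downward step a 1.9-fold lower number from compound 3 to compound 4 (0.28 log units; within the scatter) is therefore expected, one that probably does not reach beyond the scatter. Compound 4 is estimated at 110 nM, with a range from 50 nM to 250 nM.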

Compound 4, half-maximal inhibitory concentration: 200 nM
Estimate against measurement, compound 4: 1.8-fold (0.26 log units) below, within the range that was stated.
By their numbers in this assay, from the lowest: compounds 1, 2, 4 and 3 (each within the scatter of the next, the first and the last beyond it).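

In this assay, 2-methoxyphenyl in place of 3-fluorophenyl gives a 1.1-fold lower number from compound 3 to compound 4 (0.02 log units; within the scatter), so the data do not separate these two groups at this aromatic carbon. On the oxygen, methyl in place of isopropyl gives a 1.5-fold higher number from compound 2 to compound 4 (0.19 log units; within the scatter), which stays within the scatter. Methyl in place of phenyl gives a 2.5-fold higher number from compound 1 to compound 4 (0.40 log units; beyond the scatter), a modest step and the only one on this oxygen that lies beyond the scatter. Nothing available explains these steps. Going by these compounds, whether an amine or a carboxylic acid in place of the methoxy group would keep these numbers remains open.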